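Nitro to ethoxy on the benzyl ether para position

The source may hold more compounds than are shown below. What is called first, only, known or untested is meant among the compounds shown, and "the series" means these compounds.

Compound 1 `COc1cccc(OC)c1OCCNCCOc1ccccc1OCc1ccccc1Cl` gives 7.52 in a functional assay on spleen for antagonist activity at Alpha-1B adrenergic receptor (Rattus norvegicus); on this read-out higher numbers stand for higher potency (the scale is a negative logarithm) and lower numbers for lower potency. Compound 2 `COc1cccc(OC)c1OCCNCCOc1ccccc1OCc1ccc(Cl)cc1` gives 8.06. Compound 3 `COc1cccc(OC)c1OCCNCCOc1ccccc1OCc1ccc([N+](=O)[O-])cc1` gives 9.02.

Compound 3 stands highest of the three measured numbers: a number 0.96 log units higher from compound 2 to compound 3 (beyond the scatter), and a number 1.50 log units higher from compound 1 to compound 3 (beyond the scatter). Compound 4 `CCOc1ccc(COc2ccccc2OCCNCCOc2c(OC)cccc2OC)cc1` carries the change (ethoxy in place of nitro on an aromatic carbon). Within the data shown here, only one measured step touches this position: a number 0.96 log units higher from compound 2 to compound 3 (beyond the scatter), a modest gain on exchanging one para group for another. The step of a number 0.54 log units higher from compound 1 to compound 2 (beyond the scatter) concerns where the chloro sits, not the group exchanged here. Among the measured compounds shown here, no ethoxy analogue has been measured, so the size of the move is uncertain. Since compound 3 holds the highest value, 9.02, a loss is expected, a number 0.82 log units lower from compound 3 to compound 4 (beyond the scatter). Compound 4 is therefore estimated at 8.2, within 7.5 to 8.9.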

Compound 4, negative logarithm of the antagonist equilibrium constant: 8.23
Estimate against measurement, compound 4: 0.03 log units below; measured number inside the range.
By their numbers in this assay, from the lowest: compound 1; then compounds 2 and 4 (each within the scatter of the next); then compound 3.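

Nitro is not interchangeable with ethoxy at this position in this assay (a number 0.79 log units lower from compound 3 to compound 4 (beyond the scatter)) while ethoxy and chloro are not separated (a number 0.17 log units higher from compound 2 to compound 4 (within the scatter)), so among these groups only nitro stands apart. The 4-ethoxyphenyl group also keeps an edge over 2-chlorophenyl (a number 0.71 log units higher from compound 1 to compound 4 (beyond the scatter)) in the same read-out. No data here explain why nitro stands apart.

Going by these compounds, whether a nitrile, a carboxylic acid or an amine at this position would reach the level of nitro remains open. So does the effect of a longer chain in place of ethoxy.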